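The source may report more compounds than this note shows. Statements on the series, on what has been measured and on what is new or still open speak of the compounds shown alone.

Three compounds share one core and differ only in the group on an aromatic carbon. In an ADME assay on MDBK cells (Bos taurus) for cytotoxicity, read by MTT assay, with a stated time of 96 h (a higher number here means that more compound is tolerated, a lower number that less compound is tolerated), compound 1 `Oc1ccc(-c2nc3cc(C(F)(F)F)ccc3[nH]2)cc1` gives 51000 nM, compound 2 `O=[N+]([O-])c1ccc(-c2nc3cc(C(F)(F)F)ccc3[nH]2)cc1` gives 6000 nM, and compound 3 `CC(=O)Nc1ccc(-c2nc3cc(C(F)(F)F)ccc3[nH]2)cc1` gives 50000 nM. Compound 3 stands second highest of the three: a 1.0-fold lower number from compound 1 to compound 3 (0.01 log units; within the scatter), whereas an 8.3-fold higher number from compound 2 to compound 3 (0.92 log units; beyond the scatter). Compound 4 `O=C(CN1CCCCC1)Nc1ccc(-c2nc3cc(C(F)(F)F)ccc3[nH]2)cc1` extends the acetamido group of compound 3: piperidin-1-yl in place of hydrogen on a saturated chain carbon bound to a carbonyl carbon. Among the measured compounds shown here, no measured step alters this saturated chain carbon, and the two steps that reach compound 3 concern only the group on the aromatic carbon, so they give little guidance. In this assay compound 4 is expected to stay close to its parent, so that a 1.7-fold lower number from compound 3 to compound 4 (0.22 log units; within the scatter) is the expected step. The estimate for compound 4 is 30000 nM, with a range from 8000 nM to 80000 nM.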

Compound 4, half-maximal cytotoxic concentration: 6000 nM
For compound 4 the middle estimate is 5.0-fold (0.70 log units) above the measured one, outside the stated range (below it).
By their numbers in this assay, from the lowest: compounds 2 and 4 (each within the scatter of the next); then compounds 3 and 1 (each within the scatter of the next).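

In this assay, the saturated chain carbon bound to a carbonyl carbon proves sensitive: piperidin-1-yl in place of hydrogen there gives a step beyond the scatter (an 8.3-fold lower number from compound 3 to compound 4 (0.92 log units; beyond the scatter)). The acetamido group of compound 3 had matched the hydroxy group of compound 1 within the scatter (a 1.0-fold lower number from compound 1 to compound 3 (0.01 log units; within the scatter)), so that parity does not carry over to this extended acetamido group. Nothing measured here accounts for the step. The compounds shown leave open whether the ring or its nitrogen matters. A dimethylamino group, a morpholin-4-yl ring or a cyclohexyl group on the same carbon would separate these.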